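The source may hold more compounds than are shown below. What is called first, only, known or untested is meant among the compounds shown, and "the series" means these compounds.

Series notes on rat clearance.

Compound 1 `C=CC(=O)N1CC[C@H](N2C(=O)N(c3ccccc3)Cc3cnc(Nc4ccc(N5CCN(C)CC5)cc4)nc32)C1` and compound 2 `C=CC(=O)N1CC[C@H](N2C(=O)N(c3ccccc3)Cc3cnc(Nc4ccc(N5CCN(C)CC5)c(C)c4)nc32)C1` share one core and differ by a single methyl on an aromatic carbon. In an ADME assay on the whole organism (strain Sprague-Dawley) for pharmacokinetics, with Rattus norvegicus as the target, read by LC-MS, at a dose of 25 mg/kg by the oral route (a higher number here means faster removal of the compound, a lower number slower removal), compound 1 gives 203 mL/min/kg. In this assay compound 2 gives 167 mL/min/kg, a number that sits within the scatter of compound 1, as the step of a 1.2-fold lower number from compound 1 to compound 2 (0.08 log units; within the scatter) shows; no order between the two can be read from these numbers.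

Compound 3 `C=CC(=O)N1CC[C@H](N2C(=O)N(c3ccccc3)Cc3cnc(Nc4ccc(N5CCN(C)CC5)c(OC)c4)nc32)C1` is not yet measured. It differs from compound 2 in one place: methoxy in place of methyl on an aromatic carbon. Going by the values given here, the only measured step that bears on this position is a 1.2-fold lower number from compound 1 to compound 2 (0.08 log units; within the scatter), which did not leave the scatter. Among the compounds with values here, no measured step involves a methoxy. On that basis no step beyond the scatter is expected in this assay from compound 2 to compound 3, in either direction. The expected step is a 1.0-fold higher number from compound 2 to compound 3 (0.01 log units; within the scatter). For compound 3 in this assay the estimate is 170 mL/min/kg, with a range from 90 mL/min/kg to 330 mL/min/kg.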

Compound 3, clearance: 467 mL/min/kg
The estimate for compound 3 lay 2.7-fold (0.44 log units) below the measured number; measured number above the stated range.
By their numbers in this assay, from the lowest: compounds 2 and 1 (each within the scatter of the next); then compound 3.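

In this assay this carbon proves not indifferent to what it carries: methoxy gives a 2.8-fold higher number from compound 2 to compound 3 (0.45 log units; beyond the scatter) and a 2.3-fold higher number from compound 1 to compound 3 (0.36 log units; beyond the scatter) while methyl in place of hydrogen stayed within the scatter. The outcome at this site, ortho to a 4-methylpiperazin-1-yl group, therefore depends on the group placed there and not simply on the site being filled, and of the two groups only methoxy moves clearance beyond the scatter, towards faster removal. Nothing at hand says why methoxy and methyl part here.

Only hydrogen, methyl and methoxy are shown at this carbon, so it stays open whether a hydroxyl, a fluorine or a longer ether such as ethoxy would side with methyl or with methoxy. Also open, going by these compounds, is whether the same step holds with an amine other than the 4-methylpiperazin-1-yl group on this ring.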